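Trifluoromethoxy Variant of a Sulfonamide Piperidine Series

A few compounds are considered here, and "the series" means these few. Any claim that something is new, unique, unknown or untested is made for them only; others in the source may bear on it.

Measured so far in a functional assay on DLD-1 cells (Homo sapiens) for antiproliferative activity, read by CellTiter-Glo, with a stated time of 72 h; a higher number here means a weaker inhibitor, a lower number a stronger inhibitor:
Compound 1 `CC1CCN(C2CCN(S(=O)(=O)c3ccc(C#N)cc3)CC2)CC1` gives 2800 nM.
Compound 2 `CCCOc1ccc(S(=O)(=O)N2CCC(N3CCC(C)CC3)CC2)cc1` gives 452 nM.
Compound 3 `CC1CCN(C2CCN(S(=O)(=O)c3ccc(OCc4ccccc4)cc3)CC2)CC1` gives 385 nM.

Compound 3 stands at the low end of this set together with compound 2, since a 1.2-fold lower number from compound 2 to compound 3 (0.07 log units; within the scatter), while a 7.3-fold lower number from compound 1 to compound 3 (0.86 log units; beyond the scatter). Compound 4 `CC1CCN(C2CCN(S(=O)(=O)c3ccc(OC(F)(F)F)cc3)CC2)CC1` differs from compound 3 by trifluoromethyl in place of benzyl on an oxygen on an aromatic ring. Among the compounds with values here, no measured step covers this exact exchange. The steps of a 6.2-fold lower number from compound 1 to compound 2 (0.79 log units; beyond the scatter) and a 7.3-fold lower number from compound 1 to compound 3 (0.86 log units; beyond the scatter) show that two alkoxy groups of quite different size land close together, both well apart from the nitrile, so within this set the group on the oxygen seems to count for less than the oxygen itself. Compound 4 keeps that oxygen and is therefore expected to stay near the level of compound 3, with a 1.6-fold higher number from compound 3 to compound 4 (0.19 log units; within the scatter) at most slightly beyond the scatter. Compound 4 is estimated at 600 nM, in the range 250 nM to 1500 nM.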

Compound 4, half-maximal inhibitory concentration: 16 nM
For compound 4 the middle estimate is 38-fold (1.57 log units) above the measured one; measured number outside the range, below it.
By their numbers in this assay, from the lowest: compound 4; then compounds 3 and 2 (each within the scatter of the next); then compound 1.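

At the group on the oxygen on the aromatic ring, the identity of that group turns out to matter greatly in this assay: trifluoromethyl gives a 24-fold lower number from compound 3 to compound 4 (1.38 log units; beyond the scatter) against benzyl and a 28-fold lower number from compound 2 to compound 4 (1.45 log units; beyond the scatter) against propyl, although benzyl and propyl themselves lie within the scatter of each other. The oxygen alone therefore does not set the level in this set. Against the nitrile, trifluoromethoxy gives a 180-fold lower number from compound 1 to compound 4 (2.24 log units; beyond the scatter).

Going by these compounds, whether methoxy or difluoromethoxy in the same place would hold this level stays open. Nothing available bears on what lies behind this large step.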